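This account rests on a few compounds, and the source may have more. Where it says the series, first, only, none or still open, it means among the compounds named here.

Measured in a functional assay on MCF7 cells (Homo sapiens) for antiproliferative activity, read by MTT assay, with a stated time of 72 h; on this read-out higher numbers stand for weaker inhibition and lower numbers for stronger inhibition:
- compound 1 `COc1cccc(N2C(=O)COc3ccc(-c4cnc(Cl)c(NS(=O)(=O)c5ccc(F)cc5)c4)cc32)c1`: > 40000 nM
- compound 2 `COc1cccc(N2C(=O)COc3ccc(-c4cnc(OC)c(NS(=O)(=O)c5ccc(F)cc5)c4)cc32)c1`: > 40000 nM
- compound 3 `O=C1COc2ccc(-c3cnc4ccccc4c3)cc2N1c1ccc(F)cc1`: > 40000 nM

Each of these three entries is a limit of the assay and not a number.

In this assay, compound 2 stands at > 40000 nM, which is a limit. It therefore has no exact place among the compounds, and the other two entries offer no numbers to rank it against. The evidence so far is the limit of > 40000 nM in this assay, at which 3 of the 3 values shown sit.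

The next compound changes a different part of the molecule. Compound 4 `COc1ncc(-c2ccc3c(c2)N(c2ccc(Cl)cc2)C(=O)CO3)cc1NS(=O)(=O)c1ccc(F)cc1` carries 4-chlorophenyl in place of 3-methoxyphenyl on an amide-type nitrogen in a ring, and the counted difference is 4-chlorophenyl in place of 3-methoxyphenyl on an amide-type nitrogen in a ring.

For the measured compounds named here, no measured step concerns this place. Going by the values given here, the only step available, a step that the two limits leave unreadable from compound 1 to compound 2, involves methoxy in place of chloro on an aromatic carbon, and it has no readable size to carry over. With no measured size to build on, no step in either direction can be predicted with confidence, so the working expectation is that the result stays at the same limit. The expected change is a number no higher from compound 2 to compound 4 (the limit leaves the size open), and this estimate is loose.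

For compound 4 the estimated value in this assay is 40000 nM, with an expected range from 6000 nM to 80000 nM.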

Compound 4, half-maximal inhibitory concentration: 27600 nM
For compound 4 the middle estimate is 1.4-fold (0.16 log units) above the measured one, and the stated range covers the measured number.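

In this assay, compound 4 gives 27600 nM as a real number, the first among the compounds shown that is not a limit of the assay. For the compounds shown here, putting 4-chlorophenyl in place of 3-methoxyphenyl on the amide-type nitrogen in a ring therefore yields the first step here with any readable size, an at least 1.4-fold lower number from compound 2 to compound 4 (0.16 log units; that floor lies within the scatter), and since that step starts from a limit, the true gap could be larger than this floor, though the floor alone does not show a real gain. Even so, this change brings the series only just into the range the assay can read, and most of the values still stand at its edge: the limit of > 40000 nM in this assay, at which 3 of the 4 values shown sit.

The compounds shown leave open how much of the true gap lies hidden behind the limit, and whether the 4-chlorophenyl group would give a number on the shared core of compound 1, where chloro stands in place of methoxy. They also leave open what other groups at this ring nitrogen would do, such as a phenyl ring carrying a carboxylic acid or an amine, or a longer chain in place of the ring.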